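Bromo added to a coumarin-like fragment: cytotoxicity outlook

A few compounds are considered here, and "the series" means these few. Any claim that something is new, unique, unknown or untested is made for them only; others in the source may bear on it.

Measured so far:
compound 1, `CC(=O)OC[C@H]1O[C@@H](n2c(SCc3cc4cc(Br)ccc4oc3=O)nc3cncnc32)[C@H](OC(C)=O)[C@@H]1OC(C)=O`, 6700 nM
compound 2, `CC(=O)OC[C@H]1O[C@@H](n2c(SCc3cc4cc(Br)cc(Br)c4oc3=O)nc3cncnc32)[C@H](OC(C)=O)[C@@H]1OC(C)=O`, 6000 nM
compound 3, `Nc1ncnc2c1nc(SCc1cc3cc(Br)ccc3oc1=O)n2[C@@H]1O[C@H](CO)[C@@H](O)[C@H]1O`, 41000 nM

All three were tested in a functional assay on Huh-5-2 cells (Homo sapiens) for cytotoxicity, read by microscopy; a lower number here means that less compound is tolerated, a higher number that more compound is tolerated. Compound 1 gives 6700 nM and compound 2 gives 6000 nM; the two differ by bromo in place of hydrogen on an aromatic carbon and the step between them, a 1.1-fold lower number from compound 1 to compound 2 (0.05 log units; within the scatter), lies within the scatter, so the two numbers cannot be told apart. Compound 3 carries a different core; how it differs from the core of compound 1 is not broken down here. In this assay compound 3 gives 41000 nM, and compared with compound 1 this is a higher number beyond the scatter, meaning more of compound 3 is tolerated.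

Compound 4, `Nc1ncnc2c1nc(SCc1cc3cc(Br)cc(Br)c3oc1=O)n2[C@@H]1O[C@H](CO)[C@@H](O)[C@H]1O`, has not yet been measured. It differs from compound 3 by bromo in place of hydrogen on an aromatic carbon, and its place is word for word the same as in the change from compound 1 to compound 2, so this is the same change on the other core. Because the step of a 1.1-fold lower number from compound 1 to compound 2 (0.05 log units; within the scatter) stayed within the scatter, a similar outcome is expected on the core of compound 3: the expected step is a 1.1-fold lower number from compound 3 to compound 4 (0.04 log units; within the scatter). Compound 4 is therefore estimated to give 37000 nM in this assay, most likely between 15000 nM and 90000 nM.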

Compound 4, half-maximal cytotoxic concentration: 36000 nM
The estimate for compound 4 lay 1.0-fold (0.01 log units) above the measured number, within the range that was stated.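

In this assay the swap of hydrogen for bromo on the core of compound 3 gives a 1.1-fold lower number from compound 3 to compound 4 (0.06 log units; within the scatter) and so leaves compound 3 and compound 4 indistinguishable. This shows that, in these two pairs, the change carries over from one core to the other as a step too small to read, but it does not show that bromo is without effect on cytotoxicity in general, since two pairs say nothing about a third core or about any other kind of test. Set side by side, the two steps cannot be told apart, so the change behaves alike on both cores as far as this measurement can tell: the same change on two cores in this assay, a 1.1-fold lower number (0.05 log units; within the scatter) from compound 1 to compound 2 and a 1.1-fold lower number (0.06 log units; within the scatter) from compound 3 to compound 4, 1.0-fold (0.01 log units) apart, within the scatter of two such steps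

The compounds shown leave open whether a different group on that aromatic carbon, such as chloro, a methoxy group or an amine, would also leave the tolerated concentration unchanged on both cores. They also leave open which of the differences between the core of compound 1 and the core of compound 3 goes with the higher number of compound 3, as those two compounds differ in more than one place.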